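The compounds below may be only part of what the source reports. "The series", "measured", "known", "first", "only" and "open" are said of these compounds alone.

Compound 1, `Cn1nnnc1SCC(=O)N/N=C/c1ccccc1[N+](=O)[O-]`: 1600000 nM
Compound 2, `Cn1nnnc1SCC(=O)N/N=C/c1cccc([N+](=O)[O-])c1`: > 10000000 nM

Among the measured compounds shown here, compound 1 is the only compound here with an actual number on this read-out. In a functional assay on A549 cells (Homo sapiens) for cytotoxicity, read by XTT assay, with a stated time of 24 h (on this read-out higher numbers stand for weaker inhibition and lower numbers for stronger inhibition), compound 1 gives 1600000 nM. Compound 2 reached only a limit of the assay and not a number. In this assay compound 2 gives > 10000000 nM. One of the two values shown therefore sits at the limit of > 10000000 nM in this assay, at which 1 of the 2 values shown sits.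

Compound 3, `Cn1nnnc1SCC(=O)N/N=C/c1ccccc1Br`, has not yet been measured. It differs from compound 1 in a single place: bromo in place of nitro on an aromatic carbon, ortho to a large group. For the measured compounds named here, no measured pair shows what such a swap does here, so no step beyond the usual scatter is assumed in this assay in either direction. The step from compound 1 to compound 3 is expected to be a 1.3-fold higher number from compound 1 to compound 3 (0.10 log units; within the scatter). Compound 3 is accordingly estimated at 2000000 nM, with a range from 500000 nM to 10000000 nM.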

Compound 3, half-maximal inhibitory concentration: 2000000 nM
For compound 3 middle estimate and measured number coincide at the digits printed; the measured number falls inside the stated range.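

In this assay, bromo in place of nitro on an aromatic carbon, ortho to a large group, gives a 1.3-fold higher number from compound 1 to compound 3 (0.10 log units; within the scatter). Among the compounds shown here, this is the first measured swap at this place, and it shows that nitro, with 3 heavy atoms and 2 hydrogen-bond acceptors, can give way to bromo, with 1 heavy atom and 0 hydrogen-bond acceptors, without a step beyond the usual scatter. Nothing measured here offers an explanation for this result.

The compounds shown leave open whether this place would tolerate a very different group, such as an amine or a carboxylic acid, equally well. They also leave open whether any group here could bring the number down by more than the scatter.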